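Adding a Benzyloxy Group to a Chloro-Substituted Chalcone

The source may hold more compounds than are shown below. What is called first, only, known or untested is meant among the compounds shown, and "the series" means these compounds.

In a functional assay on HCT-116 cells (Homo sapiens) for antiproliferative activity, read by sulforhodamine B assay, with a stated time of 3 days, tested at 25 uM (on this read-out higher numbers stand for a stronger effect at the one concentration tested and lower numbers for a weaker effect), compound 3 `O=C(/C=C/c1ccc(Cl)cc1)c1ccccc1` gives 97.5%, second highest of the three numbers; compound 1 `O=C(/C=C/c1cccc([N+](=O)[O-])c1)c1ccccc1` gives 100%, within the scatter of compound 3, while compound 2 `O=C(/C=C/c1ccc(OCc2ccccc2)cc1)c1ccccc1` gives 52.3%, well below it. Going by the values given here, the one measured step, a number 45.2 percentage points higher from compound 2 to compound 3 (beyond the scatter), shows a benzyloxy group leaving and a chloro entering on the same ring. Compound 4 `O=C(/C=C/c1ccc(Cl)cc1)c1ccc(OCc2ccccc2)cc1` differs from compound 3 by benzyloxy in place of hydrogen on an aromatic carbon, with the chloro of compound 3 kept and the benzyloxy entering on a different ring, para to a large group. That step does not match the measured one directly, so its size is uncertain; since compound 3 already gives the high number 97.5%, the expected step of a number 12.5 percentage points lower from compound 3 to compound 4 (beyond the scatter) is a modest decrease. Compound 4 is therefore estimated at 85%, between 55% and 100%.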

Compound 4, a percentage reported as inhibition, at one concentration (the size of the read-out at that concentration, not a potency): 0.3%
The estimate for compound 4 lay 84.7 percentage points above the measured number; measured number below the stated range.
By their numbers in this assay, from the lowest: compound 4; then compound 2; then compounds 3 and 1 (each within the scatter of the next).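

Setting benzyloxy in place of hydrogen on this aromatic carbon, para to a large group, gives a number 97.2 percentage points lower from compound 3 to compound 4 (beyond the scatter) in this assay, so the chloro kept from compound 3 does not preserve the effect once this group enters. The earlier compounds had shown benzyloxy only on the other ring, and this step shows that the number also falls sharply with benzyloxy on this ring. Nothing available here accounts for the loss. As far as these compounds go, whether a methoxy group or an amine at this position would keep the effect stays open. So does whether benzyloxy here would lower the number without the chloro.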